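This account rests on a few compounds, and the source may have more. Where it says the series, first, only, none or still open, it means among the compounds named here.

Measured in a physicochemical assay for solubility, read by spectrophotometry, in phosphate buffer, with a stated time of 18 h, at pH 7.4; a higher number here means a more soluble compound, a lower number a less soluble compound:
- compound 1 `CCc1ccc(-c2nc3c(c(C)nn3-c3ccccc3)c(-c3ccccc3Br)c2C#N)cc1`: 1500 nM
- compound 2 `CCc1ccc(-c2nc3c(c(C)nn3-c3ccccc3)c(-c3ccccc3C(=O)O)c2C#N)cc1`: 33000 nM
- compound 3 `Cc1cccc(-c2nc3c(c(C)nn3-c3ccccc3)c(-c3ccccc3O)c2C#N)c1`: 42000 nM

Compound 3, at 42000 nM, stands level with compound 2, at 33000 nM, since their gap lies within the scatter. Both sit far above compound 1, at 1500 nM.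

Compound 4 `Cc1nn(-c2ccccc2)c2nc(-c3ccc(F)cc3)c(C#N)c(-c3ccccc3O)c12` has not yet been measured. It keeps the 2-hydroxyphenyl group of compound 3 and changes one other group: 4-fluorophenyl in place of 3-methylphenyl on an aromatic carbon. This is 4-fluorophenyl in place of 3-methylphenyl, on an aromatic carbon next to the ring nitrogen.

Going by the values given here, the only measured step, a 22-fold higher number from compound 1 to compound 2 (1.34 log units; beyond the scatter), is large, but it swaps bromo for carboxy and leaves this group untouched. Among the compounds with values here, it therefore says nothing direct about the new change, and no measured step does. The best guide is compound 3 itself, at 42000 nM. No step beyond the scatter is expected in this assay, and no direction can be favoured. The expected step is a 1.1-fold lower number from compound 3 to compound 4 (0.04 log units; within the scatter). Compound 4 is estimated at 38000 nM, with an expected range of 16000 nM to 80000 nM.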

Compound 4, solubility: 6000 nM
Compound 4: the middle estimate sits 6.3-fold (0.80 log units) above what was measured, outside the stated range (below it).
By their numbers in this assay, from the lowest: compound 1; then compound 4; then compounds 2 and 3 (each within the scatter of the next).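

In this assay, putting 4-fluorophenyl in place of 3-methylphenyl gives a 7.0-fold lower number from compound 3 to compound 4 (0.85 log units; beyond the scatter), even though the two groups match in heavy atoms, hydrogen-bond donors and acceptors, and net charge. Going by these compounds alone, the only earlier step, a 22-fold higher number from compound 1 to compound 2 (1.34 log units; beyond the scatter), came from a change on the 2-position of another aromatic ring, so this is the first sign that the aromatic group next to the ring nitrogen can also move the number beyond the scatter. Nothing measured here explains the drop.

This single swap removes a methyl group, adds a fluorine and moves the substituent around the ring, so the compounds shown cannot say which of these changes carries the step. Unsubstituted phenyl, 4-methylphenyl or 3-fluorophenyl at this position would pull those changes apart.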